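The source may report more compounds than this note shows. Statements on the series, on what has been measured and on what is new or still open speak of the compounds shown alone.

Values in a functional assay on HeLa cells (Homo sapiens) for cytotoxicity, read by MTT assay; on this read-out higher numbers stand for weaker inhibition and lower numbers for stronger inhibition:
- compound 1 `CCCC(O)CC(=O)O[C@H](CC=C(C)C)C1=CC(=O)c2c(O)ccc(O)c2C1=O`: 59300 nM
- compound 2 `COCCO[C@H](CC=C(C)C)C1=CC(=O)c2c(O)ccc(O)c2C1=O`: 62400 nM
- compound 3 `CC(=O)OC(C)CO[C@H](CC=C(C)C)C1=CC(=O)c2c(O)ccc(O)c2C1=O`: 40100 nM

Compound 3 cannot be separated from the other two compounds on these numbers: a 1.5-fold lower number from compound 1 to compound 3 (0.17 log units; within the scatter), and a 1.6-fold lower number from compound 2 to compound 3 (0.19 log units; within the scatter). The three values form one group within the scatter.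

Compound 4 `CC(C)=CC[C@@H](OCCO)C1=CC(=O)c2c(O)ccc(O)c2C1=O` is the next compound to be read against compound 3. The change is hydroxymethyl in place of 1-acetoxyethyl, on a saturated chain carbon bound to an oxygen on a saturated carbon (hydroxymethyl in place of 1-acetoxyethyl on a saturated chain carbon bound to an oxygen on a saturated carbon). Cut one bond further out, the same difference reads 2-acetoxypropyl to 2-hydroxyethyl.

Among the compounds with values here, the closest precedent is the step at this same place, a 1.6-fold lower number from compound 2 to compound 3 (0.19 log units; within the scatter). The changes on the oxygen on a saturated carbon, a 1.1-fold higher number from compound 1 to compound 2 (0.02 log units; within the scatter) and a 1.5-fold lower number from compound 1 to compound 3 (0.17 log units; within the scatter), bear on it less directly. Within the data shown here, all three steps stay within the scatter, although none of the measured compounds carries the 2-hydroxyethyl group itself. No step beyond the scatter is therefore expected in this assay.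

The expected step is a 1.1-fold higher number from compound 3 to compound 4 (0.05 log units; within the scatter). For compound 4 the estimated value is 45000 nM, with an expected range of 20000 nM to 90000 nM.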

Compound 4, half-maximal inhibitory concentration: 18600 nM
Beside the measured number, compound 4's estimate is 2.4-fold (0.38 log units) above it, outside the stated range (below it).
By their numbers in this assay, from the lowest: compound 4; then compounds 3, 1 and 2 (each within the scatter of the next).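

With the 2-hydroxyethyl group on the oxygen on a saturated carbon, the series shows its first separation in this assay, with compound 4 set apart from all three earlier compounds (a 2.2-fold lower number from compound 3 to compound 4 (0.33 log units; beyond the scatter); a 3.4-fold lower number from compound 2 to compound 4 (0.53 log units; beyond the scatter); a 3.2-fold lower number from compound 1 to compound 4 (0.50 log units; beyond the scatter)). The narrowest of these changes is hydrogen in place of methyl on an oxygen on a saturated carbon, so at this position removing one methyl group from the chain end is enough to move the number beyond the scatter, whereas the earlier exchanges at the same position all stayed within it. A free hydroxyl alone does not define the pattern, since compound 1 also carries one in its (2-hydroxypentyl)carbonyl group and stays in the group with compound 2 and compound 3, and the data shown offer no measured basis for explaining the step.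

On these data alone, whether the shift depends on the terminal hydroxyl itself or on the length of the chain that carries it remains open, and a 3-hydroxypropyl chain on the same oxygen would address that. Also open, as far as these compounds go, is how a 2-aminoethyl group or a carboxylic acid at the chain end would read in this assay.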